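This account rests on a few compounds, and the source may have more. Where it says the series, first, only, none or still open, it means among the compounds named here.

For the measured compounds named here, in a functional assay on COR-L23 cells (Homo sapiens) for antiproliferative activity, read by CellTiter-Glo, with a stated time of 4 days (on this read-out higher numbers stand for weaker inhibition and lower numbers for stronger inhibition), three compounds have numbers so far. Compound 1 (`CC(=O)NCc1ncc2cc(COc3ccc(C(=O)NCc4cccnc4)cc3)n(CCC3CCCCC3)c2n1`) gives 77 nM and compound 2 (`Nc1ccc(CNC(=O)Nc2ccc(CN3C(=O)c4ccccc4C3=O)cc2)cn1`) gives 57 nM while compound 3 (`C[C@H](NC(=O)CC(F)(F)F)c1ccc(NC(=O)[C@H]2C[C@@H]2c2cccnc2)cc1`) gives 18 nM as the lowest of the three numbers. The gaps from compound 3 to both of the others lie beyond the usual scatter. Compound 4 (`C[C@H](NC(=O)c1ccccc1)c1ccc(NC(=O)[C@H]2C[C@@H]2c2cccnc2)cc1`) has yet to be measured. The change from compound 3 is phenyl in place of 2,2,2-trifluoroethyl on a carbonyl carbon and in words it puts phenyl in place of 2,2,2-trifluoroethyl on a carbonyl carbon. Going by the values given here, no two measured compounds differ in one place, so the data offer no direct guide to this swap. Among the compounds with values here, the only anchor is compound 3 at 18 nM in this assay and the rest of its structure is kept. A small rise in the number is expected, with no step beyond the scatter. The estimated step of a 1.2-fold higher number from compound 3 to compound 4 (0.09 log units; within the scatter) reflects that expectation. For compound 4 the estimated value is 22 nM with an expected range from 7 nM to 70 nM when it is measured.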

Compound 4, half-maximal inhibitory concentration: 8 nM
Beside the measured number, compound 4's estimate is 2.8-fold (0.44 log units) above it, and the stated range covers the measured number.
By their numbers in this assay, from the lowest: compound 4; then compound 3; then compounds 2 and 1 (each within the scatter of the next).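

In this assay, for the compounds shown here, this swap on a carbonyl carbon whose other neighbour is an amide-type nitrogen gives a 2.3-fold lower number from compound 3 to compound 4 (0.35 log units; beyond the scatter), and it is the first comparison in this set between compounds that differ in one place. The pair shows that this position accepts an aromatic ring of carbon only and that, in this series, the 2,2,2-trifluoroethyl group and its fluorine atoms are not needed for a low number. No measurement shown bears on the reason for the step.

One pair cannot tell whether the lower number follows from the phenyl ring being present or from the 2,2,2-trifluoroethyl group being absent. The compounds shown also leave open how a pyridine ring, a cyclohexyl ring, a plain ethyl group or a phenyl ring carrying an amine would read at this position.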